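Shifting an Amino Group in a Cytotoxic Sulfone Series

A few compounds are considered here, and "the series" means these few. Any claim that something is new, unique, unknown or untested is made for them only; others in the source may bear on it.

Of the compounds shown here, three have been measured in a functional assay on PC-3 cells (Homo sapiens) for cytotoxicity, read by MTT assay, with a stated time of 72 h; a higher number here means a weaker inhibitor, a lower number a stronger inhibitor: compound 1 `Cc1ccc(S(=O)(=O)c2nc3ccccc3nc2Nc2ccc(N)cc2)cc1` with 5000 nM, compound 2 `Cc1ccc(S(=O)(=O)c2nc3ccccc3nc2Nc2cccc(N)c2)cc1` with 2000 nM, and compound 3 `Nc1ccc(Nc2nc3ccccc3nc2S(=O)(=O)c2ccc(F)cc2)cc1` with 2050 nM.

Compound 2 differs from compound 1 by 3-aminophenyl in place of 4-aminophenyl on a nitrogen on an aromatic ring, and that change gave a 2.5-fold lower number from compound 1 to compound 2 (0.40 log units; beyond the scatter). Compound 3 differs from compound 1 on the sulfone-bearing ring, by fluoro in place of methyl on an aromatic carbon, a change that gave a 2.4-fold lower number from compound 1 to compound 3 (0.39 log units; beyond the scatter). Compound 2 and compound 3 sit within the scatter of each other in this assay.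

Compound 4 `Nc1cccc(Nc2nc3ccccc3nc2S(=O)(=O)c2ccc(F)cc2)c1` has not yet been measured. It stands to compound 3 as compound 2 stands to compound 1: the difference is 3-aminophenyl in place of 4-aminophenyl on a nitrogen on an aromatic ring, and the place is described in the same words for both pairs, so this is the same change made on the core of compound 3 rather than the core of compound 1.

Among the compounds with values here, compound 4 is expected to show a 2.6-fold lower number from compound 3 to compound 4 (0.41 log units; beyond the scatter) in this assay, an expectation that rests on the single earlier instance of this change, which gave a 2.5-fold lower number from compound 1 to compound 2 (0.40 log units; beyond the scatter). Compound 4 is therefore estimated at 800 nM, with a likely range from 400 nM to 1600 nM.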

Compound 4, half-maximal inhibitory concentration: 1980 nM
Estimate against measurement, compound 4: 2.5-fold (0.39 log units) below, outside the stated range (above it).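

On the fluoro-bearing core, 3-aminophenyl in place of 4-aminophenyl gave a 1.0-fold lower number from compound 3 to compound 4 (0.02 log units; within the scatter), and with the 3-aminophenyl group in place, fluoro in place of methyl gave a 1.0-fold lower number from compound 2 to compound 4 (0.00 log units; within the scatter). The amino shift therefore went with a step beyond the scatter on one core and a step within it on the other, yet these two readings cannot be told apart, so the series neither shows that the change carries over from one core to the other nor shows that it fails to: the same change on two cores in this assay, a 2.5-fold lower number (0.40 log units; beyond the scatter) from compound 1 to compound 2 and a 1.0-fold lower number (0.02 log units; within the scatter) from compound 3 to compound 4, 2.4-fold (0.38 log units) apart, within the scatter of two such steps. The fluoro change leaves the same uncertainty, with neither a shared size nor a dependence on the other group established: the same change on two cores in this assay, a 2.4-fold lower number (0.39 log units; beyond the scatter) from compound 1 to compound 3 and a 1.0-fold lower number (0.00 log units; within the scatter) from compound 2 to compound 4, 2.4-fold (0.38 log units) apart, within the scatter of two such steps.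

With only two cores and one read-out, the compounds shown leave open how either change would behave on any further core. They also leave open what a chloro or methoxy group in place of the fluoro, or an amide in place of the amine, would do in this assay.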